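A few compounds are considered here, and "the series" means these few. Any claim that something is new, unique, unknown or untested is made for them only; others in the source may bear on it.

The series shares one core, drawn out in compound 1 `O/N=C1/C(c2c[nH]c3ccc(OCc4ccccc4)cc23)=Nc2ccc(OCc3ccccc3)cc21`, compound 2 `CC(=O)Nc1ccc2c(c1)/C(=N\O)C(c1c[nH]c3ccc(NC(C)=O)cc13)=N2` and compound 3 `Fc1ccc2c(c1)/C(=N\OCc1ccccc1)C(c1c[nH]c3ccc(F)cc13)=N2`. In a functional assay on HepG2 cells (Homo sapiens) for cytotoxicity, read by MTT assay, with a stated time of 2 days (on this read-out higher numbers stand for weaker inhibition and lower numbers for stronger inhibition), compound 1 gives 19000 nM. In this assay compound 2 gives 28200 nM. Compound 3 gives the lowest of the three numbers, 17300 nM in this assay, yet its gap to compound 1 and its gap to compound 2 both lie within the scatter, so no ranking among the three can be read from these values. Compound 4 `Cc1ccc(CO/N=C2/C(c3c[nH]c4ccc(F)cc34)=Nc3ccc(F)cc32)cc1` has not yet been measured. It differs from compound 3 by methyl in place of hydrogen on an aromatic carbon, in words: methyl in place of hydrogen on an aromatic carbon, para to a large group. No measured pair in this set carries that same change, so nothing shown gives the size of such a step. As the three measured values sit close together despite much larger differences in their substituents, the step of a 1.1-fold lower number from compound 3 to compound 4 (0.03 log units; within the scatter) is expected to stay within the scatter. Compound 4 is estimated at 16000 nM, with a range from 7000 nM to 36000 nM.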

Compound 4, half-maximal inhibitory concentration: 19600 nM
Beside the measured number, compound 4's estimate is 1.2-fold (0.09 log units) below it, within the range that was stated.
By their numbers in this assay, from the lowest: compounds 3, 1, 4 and 2 (each within the scatter of the next).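

Methyl in place of hydrogen on an aromatic carbon, para to a large group, gives a 1.1-fold higher number from compound 3 to compound 4 (0.05 log units; within the scatter) in this assay. Going by these compounds alone, this is the first comparison that isolates one place, since compounds 1, 2 and 3 differ from one another in more than one place. It shows that benzyl can go to 4-methylbenzyl without a step that stands out from the scatter in this read-out, and nothing at hand bears on why that is so.

Still open, from the compounds shown here alone, is whether an amine, a carboxylic acid or a longer chain such as butyl in place of that same hydrogen would leave the number just as undisturbed. Also open, going by these compounds, is whether a methyl on another carbon of that six-membered aromatic ring would give a step of similar size.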